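The source may report more compounds than this note shows. Statements on the series, on what has been measured and on what is new or still open speak of the compounds shown alone.

Compound 1, `COc1cccc(-c2nc3cc(Cl)ccc3[nH]2)c1Cl`: 2780 nM in an assay for inhibition of Alpha amylase (Homo sapiens), with a stated time of 10 min; a lower number here means a stronger inhibitor, a higher number a weaker inhibitor
Compound 2, `COc1ccc(Br)c(-c2nc3cc(Cl)ccc3[nH]2)c1O`: 2210 nM in this assay
Compound 3, `COc1cccc(-c2nc3cc([N+](=O)[O-])ccc3[nH]2)c1Cl`: 2780 nM in this assay

Compound 1 and compound 3 share a core and differ in one place: nitro in place of chloro on an aromatic carbon. In this assay this change gave no change at the digits printed from compound 1 to compound 3 (within the scatter). Compound 2 carries a different core; the difference between the core of compound 1 and that of compound 2 is not broken down here. Its number in this assay lies within the scatter of both compound 1 and compound 3, so no order among the three can be read from these values.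

Compound 4, `COc1ccc(Br)c(-c2nc3cc([N+](=O)[O-])ccc3[nH]2)c1O`, has not yet been measured in this assay. It stands to compound 2 as compound 3 stands to compound 1: nitro in place of chloro on an aromatic carbon. The place of the change is described in the same words for both pairs, so it is the same change. Given that the earlier instance produced no change at the digits printed from compound 1 to compound 3 (within the scatter), the step to compound 4 is expected to be a 1.0-fold lower number from compound 2 to compound 4 (0.00 log units; within the scatter). Compound 4 is therefore estimated at 2200 nM in this assay, with a range from 1100 nM to 4400 nM.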

Compound 4, half-maximal inhibitory concentration: 2290 nM
Compound 4: the middle estimate sits 1.0-fold (0.02 log units) below what was measured; the range from low to high includes it.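

Putting nitro in place of chloro on the core of compound 2 gave a 1.0-fold higher number from compound 2 to compound 4 (0.02 log units; within the scatter) in this assay. Set beside the same change on the core of compound 1, the two steps agree: the same change on two cores in this assay, no change at the digits printed (within the scatter) from compound 1 to compound 3 and a 1.0-fold higher number (0.02 log units; within the scatter) from compound 2 to compound 4, 1.0-fold (0.02 log units) apart, within the scatter of two such steps. This shows that, on these two cores, the change carried over as a step within the scatter, but it rests on two pairs only, says nothing about other cores, and, with neither step beyond the scatter, cannot show whether a larger step would carry over in the same way.

The compounds shown leave open what an amine or a carboxylic acid would give in place of chloro or nitro on the same aromatic carbon in this assay. They also leave open how the separate differences between the two cores bear on the numbers, as no pair shown isolates any one of them.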